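The compounds below may be only part of what the source reports. "The series", "measured", "known", "first", "only" and "open" are said of these compounds alone.

Measured compounds in this part of the series:

compound 1, `CCCCc1nc(=O)c(S(=O)(=O)c2ccc(-c3cccnc3)cc2)c(O)n1-c1c(OC)cccc1OC`, 88%
compound 2, `CCCCc1[nH]c(=O)c(S(=O)(=O)c2ccc(-c3cccnc3OC)cc2)c(O)c1-c1c(OC)cccc1OC`, 72%
compound 3, `CCCCc1[nH]c(=O)c(S(=O)(=O)c2ccc(-n3cc(Cl)ccc3=O)cc2)c(O)c1-c1c(OC)cccc1OC`, 97%

In an ADME assay on microsomes from liver (Homo sapiens) for metabolic stability, using NADPH, with a stated time of 10 min (on this read-out lower numbers stand for a less stable compound and higher numbers for a more stable compound), compound 1 gives 88%, the second highest of the three numbers. Compound 3 gives 97%, which lies within the scatter of compound 1. Compound 2 gives 72%, which lies beyond the scatter below compound 1.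

Going by the values given here, the only single-point step among the measured compounds is a number 25 percentage points higher from compound 2 to compound 3 (beyond the scatter). That step concerns a different part of the molecule, on a core that is not the core of compound 1, and so does not bear on the change considered here.

Compound 4, `CCCCc1nc(=O)c(S(=O)(=O)c2ccc(C)cc2)c(O)n1-c1c(OC)cccc1OC`, differs from compound 1 by methyl in place of pyridin-3-yl on an aromatic carbon. Among the compounds with values here, no measured pair shows this change, so the expectation rests on compound 1 alone, whose value of 88% is already high on this read-out, and on the possibility of a moderate move in either direction that cannot be anchored by data. Compound 4 is therefore expected to give about 80%, with a range from 55% to 97%. This estimate means a number 8 percentage points lower from compound 1 to compound 4 (within the scatter), a step that is expected to stay near the scatter rather than clearly beyond it.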

Compound 4, percent of the compound remaining: 94%
Compound 4: the middle estimate sits 14 percentage points below what was measured; low and high end bracket the measured number.
By their numbers in this assay, from the lowest: compound 2; then compounds 1, 4 and 3 (each within the scatter of the next).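

In this assay, methyl in place of pyridin-3-yl on this aromatic carbon, para to a large group, gives a number 6 percentage points higher from compound 1 to compound 4 (within the scatter). On the core of compound 1, the read-out therefore does not separate 4-(pyridin-3-yl)phenyl from 4-methylphenyl, so this position accepts both the six-membered aromatic ring and a single carbon without a step beyond the scatter. Nothing at hand gives a reason for this result.

Open, going by these compounds, is how a carboxylic acid, an amine or a longer chain at this position would read in this assay, as the two groups compared here mark only two points. Also open, on these data alone, is whether the same change would give a similar step on the core shared by compound 2 and compound 3.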